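Chloro for amino on the shared core: an expected dissociation constant

A few compounds are considered here, and "the series" means these few. Any claim that something is new, unique, unknown or untested is made for them only; others in the source may bear on it.

The account follows a single change from compound 1 `CCOc1cc(CN2CCC(NC(=O)c3ccc(N)nc3)CC2)cc(OCC)c1-c1ccc(F)cc1` to compound 4 `CCOc1cc(CN2CCC(NC(=O)c3ccc(Cl)nc3)CC2)cc(OCC)c1-c1ccc(F)cc1`. For the measured compounds named here, in a physicochemical assay for acid dissociation, read by spectrophotometry, compound 1 gives 7.86, the highest of the two numbers so far; its nearest neighbour is compound 3 `CCOc1cc(CN2CCC(NC(=O)c3ccc(N)nc3)CC2)cc(OCc2ccccc2)c1-c1ccc(F)cc1`, which gives 7.66 in this assay, and the step of a number 0.20 log units lower from compound 1 to compound 3 (within the scatter) lies within the scatter. Compound 2 `CCOc1cc(CN2CCC[C@@H](NC(=O)c3cncc(C)c3)CC2)cc(OCC)c1F` returned "not determined" (no result reported) in this assay, so no number stands for it. Compound 4 differs from compound 1 in one place: chloro in place of amino on an aromatic carbon. Going by the values given here, no measured step touches the same place; the only step seen, from phenyl in place of methyl on a saturated chain carbon bound to an oxygen on an aromatic ring, stayed within the scatter. With nothing to point elsewhere, the account expects no movement beyond the scatter, the step of a number 0.06 log units lower from compound 1 to compound 4 (within the scatter) being the estimate. Compound 4 is therefore estimated at 7.8, within a range from 7.4 to 8.2.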

Compound 4, acid dissociation constant: 7.8
The estimate for compound 4 equals the measured number at the digits printed, and the stated range covers the measured number.
By their numbers in this assay, from the lowest: compounds 3, 4 and 1 (each within the scatter of the next).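

In this assay, for the compounds shown here, chloro in place of amino on an aromatic carbon, the first measured change at this position, gives a number 0.06 log units lower from compound 1 to compound 4 (within the scatter). Going by these compounds alone, the earlier compounds showed only a change on the chain bound through oxygen, so this is the first sign that the number can stay within the scatter when the pyridine end changes from 6-aminopyridin-3-yl to 6-chloropyridin-3-yl, even though the hydrogen-bond donor and acceptor counted for amino are absent from chloro. Nothing available bears on why this change at the carbon next to the ring nitrogen gives this result.

The compounds shown leave open how a methoxy group, a dimethylamino group or a carboxylic acid at this carbon would read. They also leave open whether the same swap would give a similar step on the core of compound 3.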